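A Hydroxypropyl Branch on a Bombesin Receptor Agonist

The source may hold more compounds than are shown below. What is called first, only, known or untested is meant among the compounds shown, and "the series" means these compounds.

Of the compounds shown here, two of a shared core have been measured so far. Compound 1 `CCCCc1cnc(CCc2ccc(-c3ccccc3C(=O)O)cc2)[nH]1` carries only hydrogen at the chain carbon that joins the core to the aryl group; in an in vitro functional assay on cells for agonist activity at Bombesin receptor subtype-3 (Mus musculus), read by luminescence and calcium flux (on this read-out higher numbers stand for an effect only at larger amounts of compound and lower numbers for an effect already at smaller amounts), compound 1 gives 93 nM. Compound 2 `CCCCc1cnc(C(CC)Cc2ccc(-c3ccccc3C(=O)O)cc2)[nH]1` carries an ethyl branch at that carbon, and in this assay compound 2 gives 340 nM, the higher of the two numbers; the step of a 3.7-fold higher number from compound 1 to compound 2 (0.56 log units; beyond the scatter) lies beyond the scatter.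

Compound 3 `CCCCc1cnc(C(CCCO)Cc2ccc(-c3ccccc3C(=O)O)cc2)[nH]1` extends the branch of compound 2: hydroxymethyl in place of hydrogen on a saturated chain carbon, three bonds along the chain from an aromatic carbon. Among the measured compounds shown here, only one measured step bears on this change, the branching step a 3.7-fold higher number from compound 1 to compound 2 (0.56 log units; beyond the scatter), which shows that lengthening the branch at this carbon from nothing to ethyl cost a modest amount. Nothing measured speaks to a hydroxyl group on that branch, so the direction of the further extension is uncertain; the expectation is a step of a 1.2-fold higher number from compound 2 to compound 3 (0.07 log units; within the scatter), within or barely beyond the scatter, in this assay. Compound 3 is therefore estimated at 400 nM, with a range from 130 nM to 1300 nM.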

Compound 3, half-maximal effective concentration: 238 nM
Compound 3: middle estimate off by 1.7-fold (0.23 log units), on the high side, within the range that was stated.
By their numbers in this assay, from the lowest: compound 1; then compounds 3 and 2 (each within the scatter of the next).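

In this assay, the step of a 1.4-fold lower number from compound 2 to compound 3 (0.15 log units; within the scatter) means that ethyl and 3-hydroxypropyl at this saturated chain carbon cannot be told apart on this read-out. The earlier compounds shown here showed a modest cost only for an ethyl branch, whereas the step of a 2.6-fold higher number from compound 1 to compound 3 (0.41 log units; beyond the scatter) shows that a branch ending in a hydroxyl group also stands beyond the scatter from the unbranched compound. Of the three compounds, compound 1, with hydrogen at this carbon, therefore still has the lowest number, and neither branch shown matches it.

No supporting data are available to explain these numbers at this position. As far as these compounds go, it remains open whether an amine or a carboxylic acid at the end of this branch, or a longer chain, would stand apart from compound 3 in this assay, and whether any branch at this carbon can come within the scatter of compound 1.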